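This account rests on a few compounds, and the source may have more. Where it says the series, first, only, none or still open, it means among the compounds named here.

For the measured compounds named here, compound 3 `COCCN(Cc1cccs1)C(=O)COc1ccc(C)cc1` is one of three compounds measured in an assay on HEK293 cells for agonist activity at transient receptor potential cation channel subfamily M member 8 (Homo sapiens), read by fluorescence and calcium flux, with a stated time of 15 min; on this read-out lower numbers stand for an effect already at smaller amounts and higher numbers for an effect only at larger amounts of compound. In this assay compound 3 gives 400 nM and stands level with compound 2 `Cc1ccc(OCC(=O)N(C)Cc2cccs2)cc1`, which gives 400 nM; together they are the lowest of the three numbers, while compound 1 `Cc1ccc(OCC(=O)N(Cc2cccs2)c2nccs2)cc1` gives 2240 nM. The step of no change at the digits printed from compound 2 to compound 3 (within the scatter) lies within the scatter, whereas a 5.6-fold lower number from compound 1 to compound 2 (0.75 log units; beyond the scatter) and a 5.6-fold lower number from compound 1 to compound 3 (0.75 log units; beyond the scatter) are modest and beyond it. Compound 4 `Cc1ccc(OCC(=O)N(Cc2cccs2)c2cnccn2)cc1` differs from compound 3 by pyrazin-2-yl in place of 2-methoxyethyl on an amide-type nitrogen. The bearing step is a 5.6-fold lower number from compound 1 to compound 3 (0.75 log units; beyond the scatter), in which 1,3-thiazol-2-yl gave way to 2-methoxyethyl; compound 4 reverses that kind of exchange, so a modest rise in this assay is expected, roughly a 5.0-fold higher number from compound 3 to compound 4 (0.70 log units; beyond the scatter). Compound 4 is therefore estimated at 2000 nM, expected between 700 nM and 6000 nM.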

Compound 4, half-maximal effective concentration: 1240 nM
The estimate for compound 4 lay 1.6-fold (0.21 log units) above the measured number, within the range that was stated.
By their numbers in this assay, from the lowest: compounds 2 and 3 (each within the scatter of the next); then compounds 4 and 1 (each within the scatter of the next).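

In this assay, pyrazin-2-yl on the amide-type nitrogen stands with 1,3-thiazol-2-yl rather than with the open chains: the step of a 1.8-fold lower number from compound 1 to compound 4 (0.26 log units; within the scatter) stays within the scatter, whereas a 3.1-fold higher number from compound 3 to compound 4 (0.49 log units; beyond the scatter) and a 3.1-fold higher number from compound 2 to compound 4 (0.49 log units; beyond the scatter) are modest rises. Among the four compounds, then, both aromatic rings at this place give higher numbers than methyl and 2-methoxyethyl, and the two rings cannot be told apart. Nothing at hand explains this difference. On these data alone, whether a plain phenyl ring or a chain ending in an amine would follow the rings or the chains remains open.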